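The source may hold more compounds than are shown below. What is called first, only, known or untested is meant among the compounds shown, and "the series" means these compounds.

Measured in an ADME assay on Vero cells (Chlorocebus sabaeus) for cytotoxicity, read by fluorescence and resazurin assay, with a stated time of 3 days; a higher number here means that more compound is tolerated, a lower number that less compound is tolerated:
- compound 1 `CCCCCCCCCCCCNc1ncnc2c1ncn2[C@@H](CC(=O)OCC)[C@H]1O[C@@H]2OC(C)(C)O[C@@H]2[C@H]1OCc1ccccc1`: 81500 nM
- compound 2 `COC(=O)C[C@H]([C@H]1O[C@@H]2OC(C)(C)O[C@@H]2[C@H]1OCc1ccccc1)n1cnc2c(N)ncnc21`: 86300 nM
- compound 3 `CC1(C)O[C@H]2O[C@H]([C@H](CCO)n3cnc4c(NCc5ccccc5)ncnc43)[C@H](OCc3ccccc3)[C@H]2O1`: 61200 nM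

Compound 2, at 86300 nM, lies within the scatter of both compound 1 and compound 3. Compound 4 `COC(=O)C[C@@H]([C@H]1O[C@@H]2OC(C)(C)O[C@@H]2[C@H]1OCc1ccccc1)n1cnc2c(N)ncnc21` is the next case: the two compounds have the same atoms and bonds and differ only in configuration as drawn: 1 of 5 stereo elements differ; a stereocentre at a saturated chain carbon is drawn R in compound 2 and S in compound 4. A stereocentre at a saturated chain carbon is drawn R in compound 2 and S in compound 4. Within the data shown here, no measured pair shows what such a change does, so the expectation rests only on the close grouping of the three values. In this assay the estimated step is a 1.1-fold lower number from compound 2 to compound 4 (0.03 log units; within the scatter), with none expected beyond the scatter. Compound 4 is expected at 80000 nM, within an estimated range of 45000 nM to 130000 nM.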

Compound 4, half-maximal cytotoxic concentration: 68400 nM
Compound 4: middle estimate off by 1.2-fold (0.07 log units), on the high side; measured number inside the range.
By their numbers in this assay, from the lowest: compounds 3, 4, 1 and 2 (each within the scatter of the next).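

In this assay, among these compounds, the inversion at the saturated chain carbon gives a 1.3-fold lower number from compound 2 to compound 4 (0.10 log units; within the scatter), the first direct reading of this change. The comparison concerns this stereocentre alone: the fact that compounds 2 and 4 differ only in the configuration as drawn. For this pair, the drawn configuration at this carbon produces no difference beyond the scatter.

This single pair cannot show whether the result extends to other members of the series. Going by these compounds, it remains open whether the inversion would stay within the scatter with a carboxylic acid in place of the methyl ester.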